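A few compounds are considered here, and "the series" means these few. Any claim that something is new, unique, unknown or untested is made for them only; others in the source may bear on it.

The three measured compounds share one core. Compound 1 `Cc1nn(-c2ncnc3nc[nH]c23)c2c1C(OCC(=O)c1ccc(F)cc1)CC(=O)N2` gives 3 nM in a functional assay on HEK293 cells for agonist activity at G-protein coupled receptor 39 (Homo sapiens), read by scintillation proximity assay and inositol phosphate accumulation, with a stated time of 75 min, in the presence of a further agent that is not named here; on this read-out lower numbers stand for an effect already at smaller amounts and higher numbers for an effect only at larger amounts of compound; compound 2 `Cc1noc(C)c1COC1CC(=O)Nc2c1c(C)nn2-c1ncnc2nc[nH]c12` gives 5 nM; compound 3 `Cc1nn(-c2ncnc3nc[nH]c23)c2c1C(c1ccc(F)cc1Cl)CC(=O)N2` gives 9 nM. Compound 2 holds the second highest of these three numbers, yet its steps to both neighbours stay within the scatter: a 1.7-fold higher number from compound 1 to compound 2 (0.22 log units; within the scatter) and a 1.8-fold higher number from compound 2 to compound 3 (0.26 log units; within the scatter). Compound 4 `Cc1nn(-c2ncnc3nc[nH]c23)c2c1C(OCc1ccc(Cl)cc1Cl)CC(=O)N2` differs from compound 2 in one place: 2,4-dichlorophenyl in place of 3,5-dimethyl-1,2-oxazol-4-yl on a saturated chain carbon bound to an oxygen on a saturated carbon. The two steps already seen at or near this place, from compound 1 to compound 2 and from compound 2 to compound 3, exchanged aryl or heteroaryl groups without moving the number beyond the scatter. Compound 4 is therefore expected to show no step beyond the scatter, no change at the digits printed from compound 2 to compound 4 (within the scatter), with an estimated 5 nM and a range from 2 nM to 15 nM.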

Compound 4, half-maximal effective concentration: 4 nM
Beside the measured number, compound 4's estimate is 1.3-fold (0.10 log units) above it, and the stated range covers the measured number.
By their numbers in this assay, from the lowest: compounds 1, 4, 2 and 3 (each within the scatter of the next, the first and the last beyond it).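

The 2,4-dichlorophenyl group has 0 hydrogen-bond acceptors against 2 in the 3,5-dimethyl-1,2-oxazol-4-yl group it replaces, yet this exchange gives a 1.3-fold lower number from compound 2 to compound 4 (0.10 log units; within the scatter), and its exchange for (4-fluorophenyl)carbonyl gives a 1.3-fold higher number from compound 1 to compound 4 (0.12 log units; within the scatter). Among these compounds, on the saturated ring carbon, (2,4-dichlorobenzyl)oxy in place of 2-chloro-4-fluorophenyl gives the first one-place step beyond the scatter, though a modest one: a 2.3-fold lower number from compound 3 to compound 4 (0.35 log units; beyond the scatter). No measurement shown accounts for any of these steps.

The compounds shown leave open how the number would respond to an amine, a carboxylic acid or a longer chain at this place.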